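Alkoxy chain extension on the aryl oxygen of compound 3

This account rests on a few compounds, and the source may have more. Where it says the series, first, only, none or still open, it means among the compounds named here.

Measured so far:
compound 1 `COc1cccc(CCCNC(C)=O)c1` gives 0.751 nM
compound 2 `COc1ccc(O)c(CCCNC(C)=O)c1` gives 46.2 nM
compound 3 `CCOc1ccc(OC)cc1CCCNC(C)=O` gives 1.59 nM

In an assay on CHO cells for displacement of a labelled ligand from melatonin receptor type 1B (Homo sapiens), read by scintillation counting, with a stated time of 60 min (on this read-out lower numbers stand for stronger inhibition and higher numbers for weaker inhibition), compound 3 stands second of the three numbers: compound 1 sits beneath it by a 2.1-fold higher number from compound 1 to compound 3 (0.33 log units; beyond the scatter), while compound 2 lies far above it, the gap being a 29-fold lower number from compound 2 to compound 3 (1.46 log units; beyond the scatter). Both steps are beyond the scatter.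

Compound 4 `COc1ccc(OCCc2ccccc2)c(CCCNC(C)=O)c1` has not been measured. It differs from compound 3 by phenyl in place of hydrogen on a saturated chain carbon, two bonds along the chain from an oxygen on an aromatic ring; read one bond further out, the ethoxy of compound 3 becomes phenethyloxy.

Among the compounds with values here, two measured steps bear on the oxygen substituent at this carbon. From hydrogen to ethyl on that oxygen the number dropped sharply, a 29-fold lower number from compound 2 to compound 3 (1.46 log units; beyond the scatter). Ethoxy in place of hydrogen, however, raised the number only modestly, a 2.1-fold higher number from compound 1 to compound 3 (0.33 log units; beyond the scatter). Within the data shown here, neither step is the same change as the one here, and no compound shows a longer chain or an aromatic group on this oxygen. The change to compound 4 is therefore judged by extension only: an alkyl group on the oxygen was well tolerated, and a further added phenyl is expected to shift the number little, most likely slightly upward, the step from compound 3 to compound 4 in this assay estimated as a 1.9-fold higher number from compound 3 to compound 4 (0.28 log units; within the scatter).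

Compound 4 is expected to give about 3 nM in this assay, within a range from 0.6 nM to 15 nM.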

Compound 4, inhibition constant: 13.4 nM
Compound 4: the middle estimate sits 4.5-fold (0.65 log units) below what was measured; measured number inside the range.
By their numbers in this assay, from the lowest: compound 1; then compound 3; then compound 4; then compound 2.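

In this assay the phenyl added to the ethyl on this oxygen is not a silent change: the step is an 8.4-fold higher number from compound 3 to compound 4 (0.93 log units; beyond the scatter) and lies beyond the scatter, so ethyl and phenethyl do not read alike here. Phenethyl in place of the hydrogen on this oxygen still lowers the number, with a 3.4-fold lower number from compound 2 to compound 4 (0.54 log units; beyond the scatter) as its step against a 29-fold lower number from compound 2 to compound 3 (1.46 log units; beyond the scatter) for ethyl, so the drop seen on substituting this oxygen persists with the larger group but shrinks. Nothing available accounts for the rise on adding the phenyl.

From the compounds shown here alone, whether that rise follows the added chain length or the aromatic ring itself stays open, and a butyl chain or a cyclohexylethyl group on this oxygen would separate the two readings. Also open, going by these compounds, is how a terminal amine or carboxylic acid in place of the phenyl would read in this assay on the same core.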